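Methylamino for Methoxy on a Thienyl Nucleoside

The source may report more compounds than this note shows. Statements on the series, on what has been measured and on what is new or still open speak of the compounds shown alone.

In a functional assay on CCRF-CEM cells (Homo sapiens), read by MTT assay, with a stated time of 72 h (a higher number here means a weaker inhibitor, a lower number a stronger inhibitor), compound 1 `COc1ncnc2c1c(-c1ccoc1)cn2[C@@H]1O[C@H](CO)[C@@H](O)[C@H]1O` gives 110 nM. Compound 2 `COc1ncnc2c1c(-c1cccs1)cn2[C@@H]1O[C@H](CO)[C@@H](O)[C@H]1O` gives 90 nM, the lowest of the two numbers shown, with compound 1 nearest: a 1.2-fold lower number from compound 1 to compound 2 (0.09 log units; within the scatter). For compound 3 `COc1nc(N)nc2c1c(-c1cccs1)cn2[C@@H]1O[C@H](CO)[C@@H](O)[C@H]1O` the assay reports only a limit, > 20000 nM. The step of an at least 220-fold higher number from compound 2 to compound 3 (2.34 log units; beyond the scatter) is large, and the limit of > 20000 nM in this assay, at which 1 of the 3 values shown sits, marks that limit. Compound 4 `CNc1ncnc2c1c(-c1cccs1)cn2[C@@H]1O[C@H](CO)[C@@H](O)[C@H]1O` differs from compound 2 by methylamino in place of methoxy on an aromatic carbon. Neither measured step touches this group: one is thiophen-2-yl in place of furan-3-yl on an aromatic carbon, the other amino in place of hydrogen on an aromatic carbon. Hence no step beyond the scatter is expected in this assay, a 1.1-fold lower number from compound 2 to compound 4 (0.05 log units; within the scatter). Compound 4 is expected to give 80 nM, between 25 nM and 300 nM.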

Compound 4, half-maximal inhibitory concentration: > 20000 nM
Compound 4: a limit, no number; the forecaster's own chance of this, stated with the estimate: 5%; middle value at least 250-fold (2.39 log units) from the limit.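

On the thiophen-2-yl compounds, methylamino in place of methoxy is no small exchange in this assay: an at least 220-fold higher number from compound 2 to compound 4 (2.34 log units; beyond the scatter). Compound 4 gives > 20000 nM, which is a limit and not a number. Earlier, only the amino step had reached this limit, and now a swap of oxygen for nitrogen on the carbon that carries methoxy reaches it too: the limit of > 20000 nM in this assay, at which 2 of the 4 values shown sit.

From the compounds shown here alone, how far compound 4 lies beyond the limit remains unknown. The compounds shown also leave open whether the added hydrogen-bond donor matters, which a dimethylamino or ethoxy group at this place could test.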